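The compounds below may be only part of what the source reports. "The series", "measured", "known", "first", "only" and "open" are said of these compounds alone.

Compound 1, `COC(=O)C[C@H](NC(=O)OC(C)(C)C)C(=O)N(Cc1ccc(F)cc1)C1(C(=O)NCc2ccccc2)CCN(Cc2ccccc2)CC1`, carries a benzyl on an amine nitrogen in a ring and a benzyl on an amide-type nitrogen. In an ADME assay on MDCK cells (Canis lupus familiaris) for cytotoxicity, read by microscopy, with a stated time of 72 h (on this read-out lower numbers stand for higher toxicity in this test and higher numbers for lower toxicity in this test), compound 1 gives a limit of the assay, > 100000 nM. Compound 2, `COC(=O)C[C@H](NC(=O)OC(C)(C)C)C(=O)N(Cc1ccc(F)cc1)C1(C(=O)NCc2ccccc2)CCNCC1`, has hydrogen in place of benzyl on the amine nitrogen in a ring; in this assay compound 2 gives 100000 nM, a step of a number no higher from compound 1 to compound 2 (the limit leaves the size open). Compound 3, `COC(=O)C[C@H](NC(=O)OC(C)(C)C)C(=O)N(Cc1ccc(F)cc1)C1(C(=O)NC2CCCCC2)CCN(Cc2ccccc2)CC1`, has cyclohexyl in place of benzyl on the amide-type nitrogen, and in this assay compound 3 gives 100000 nM, a step of a number no higher from compound 1 to compound 3 (the limit leaves the size open). Compound 3 thus stands level with compound 2 at the digits shown. The remaining value, that of compound 1, is a limit (the limit of > 100000 nM in this assay, at which 1 of the 3 values shown sits).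

Compound 4, `COC(=O)C[C@H](NC(=O)OC(C)(C)C)C(=O)N(Cc1ccc(F)cc1)C1(C(=O)NC(C)(C)C)CCN(Cc2ccccc2)CC1`, differs from compound 3 in one place: tert-butyl in place of cyclohexyl on an amide-type nitrogen. Among the compounds with values here, the one measured step at the same amide-type nitrogen, a number no higher from compound 1 to compound 3 (the limit leaves the size open), leaves its size open, and the step of a number no higher from compound 1 to compound 2 (the limit leaves the size open) at another position is likewise open. Nothing in the three values points to a change beyond the scatter. Compound 4 is therefore expected to sit at about the same level, a step of no change at the digits printed from compound 3 to compound 4 (within the scatter), with the estimate 100000 nM between 50000 nM and 200000 nM.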

Compound 4, minimum cytotoxic concentration: 80000 nM
Compound 4: the middle estimate sits 1.3-fold (0.10 log units) above what was measured; low and high end bracket the measured number.
By their numbers in this assay, from the lowest: compounds 4, 2 and 3 (each within the scatter of the next).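

Within the data shown here, at the amide-type nitrogen the earlier compounds gave only a step of open size, whereas tert-butyl in place of cyclohexyl now gives a readable one, a 1.3-fold lower number from compound 3 to compound 4 (0.10 log units; within the scatter), so in this assay losing the six-membered ring of carbon only and going from six heavy atoms to four moves the number by no more than the scatter. Tert-butyl in place of benzyl at the same nitrogen gives an at least 1.2-fold lower number from compound 1 to compound 4 (0.09 log units; that floor lies within the scatter), which fixes a floor for that step but not its full size. That step rests on a limit of the assay, the value of compound 1: the limit of > 100000 nM in this assay, at which 1 of the 4 values shown sits.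

The compounds shown leave open whether this level would hold with a group of another kind on the amide-type nitrogen, such as an amine, a carboxylic acid or a longer alkyl chain, since cyclohexyl, tert-butyl and benzyl are the only groups shown there. They also leave open whether tert-butyl would give the same level with hydrogen in place of benzyl on the amine nitrogen in a ring, a combination that does not appear among them.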